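Three Weak Inhibitors and a Fourth Still Untested

The compounds below may be only part of what the source reports. "The series", "measured", "known", "first", "only" and "open" are said of these compounds alone.

Compound 1 `COc1ccc(C(c2ccccc2O)c2cccc3ccccc23)c(OC)c1OC` — > 20000 nM
Compound 2 `COc1ccc(/C(=N/O)c2cccc3ccccc23)c(OC)c1OC` — > 20000 nM
Compound 3 `COc1ccc(C(O)(Cc2ccccc2)c2cccc3ccccc23)c(OC)c1OC` — 12400 nM

In a functional assay on THP-1 cells (Homo sapiens) for inhibition, read by sulforhodamine B assay, with a stated time of 48 h (a lower number here means a stronger inhibitor, a higher number a weaker inhibitor), compound 1 gives > 20000 nM. This reading is a limit of the assay rather than a number, so compound 1 is known only to be a weak inhibitor. Compound 2 likewise gives > 20000 nM, again a limit and not a number. Only compound 3 gives a measured number, 12400 nM, which still marks a weak inhibitor. The picture is summed up by the limit of > 20000 nM in this assay, at which 2 of the 3 values shown sit. Among the measured compounds shown here, no step between two measured compounds is available, so nothing here shows how a single change shifts potency.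

Compound 4 `COc1ccc(C(c2ccc(OCCO)cc2)c2cccc3ccccc23)c(OC)c1OC` has not yet been tested. It differs from compound 1 in one place: 4-(2-hydroxyethoxy)phenyl in place of 2-hydroxyphenyl on a saturated chain carbon bound to two aromatic carbons. With compound 1 sitting at a limit, the step expected from compound 1 to compound 4 in this assay cannot be anchored well; no change beyond the scatter is expected, and a second limit is the likeliest outcome. Compound 4 is therefore estimated at 25000 nM, with a range from 8000 nM to 70000 nM, meaning an expected step that the limit leaves unreadable from compound 1 to compound 4.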

Compound 4, half-maximal inhibitory concentration: 16600 nM
Compound 4: middle estimate off by 1.5-fold (0.18 log units), on the high side; measured number inside the range.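

Compound 4 gives 16600 nM in this assay, so this compound has a measured number and remains a weak inhibitor with a larger group on the saturated chain carbon bound to two aromatic carbons, 10 heavy atoms in place of 7. Compound 1 gives > 20000 nM, which is a limit and not a number. The change from 2-hydroxyphenyl to 4-(2-hydroxyethoxy)phenyl can therefore be read only as a floor, an at least 1.2-fold lower number from compound 1 to compound 4 (0.08 log units; that floor lies within the scatter), so it shows no gain beyond the scatter, although the real step may be larger.

From the compounds shown here alone, it remains open whether any group at this position can give a strong inhibitor, for example a phenyl ring carrying a longer chain, or a chain that ends in an amine or a carboxylic acid rather than a hydroxyl. Steps among the other compounds cannot be read, and comparisons within this small set stay limited by the ceiling of the measurement: the limit of > 20000 nM in this assay, at which 2 of the 4 values shown sit.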